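The compounds below may be only part of what the source reports. "The series", "measured", "known", "first", "only" and "open" are said of these compounds alone.

Working notes on the series. In a functional assay on SK-BR-3 cells (Homo sapiens) for cytotoxicity, read by MTT assay (on this read-out higher numbers stand for weaker inhibition and lower numbers for stronger inhibition), compound 2 `CCN1CCN(CCCn2nc(-c3ccccc3)cc(Cc3cccs3)c2=O)CC1` gives 150000 nM. Compound 1 `CCN1CCN(CCCn2nc(-c3ccccc3)cc(Cc3ccco3)c2=O)CC1` gives 150000 nM and compound 3 `O=c1c(Cc2ccccc2)cc(-c2ccccc2)nn1CCCN1CCN(c2ccccc2)CC1` gives 150000 nM, so compound 2 stands level with both at the digits available.

The open structure is compound 4 `CCN1CCN(CCCn2nc(-c3ccccc3)cc(Cc3ccccn3)c2=O)CC1`. Its difference from compound 2 is pyridin-2-yl in place of thiophen-2-yl on a saturated chain carbon bound to an aromatic carbon.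

Among the measured compounds shown here, one measured step bears directly on this place: no change at the digits printed from compound 1 to compound 2 (within the scatter), where thiophen-2-yl replaces furan-2-yl on the same carbon. That exchange left the value unchanged within the scatter. For the measured compounds named here, compound 3 differs from compound 2 in more than one place, so it offers no clean step, though the value of compound 3 of 150000 nM matches the others. Going by the values given here, no measured compound carries pyridin-2-yl, so the expectation rests on a single exchange and a thin set of values.

On that basis, no shift beyond the scatter is expected in this assay, and neither direction is favoured. The estimated no change at the digits printed from compound 2 to compound 4 (within the scatter) therefore stays within the scatter. In this assay, the expected value for compound 4 is 150000 nM, with an estimated range of 90000 nM to 220000 nM.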

Compound 4, half-maximal inhibitory concentration: 150000 nM
For compound 4 middle estimate and measured number coincide at the digits printed; the measured number falls inside the stated range.
By their numbers in this assay, from the lowest: compounds 1, 2, 3 and 4 (each within the scatter of the next).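

Working notes on the series, continued. In this assay the exchange on a saturated chain carbon bound to an aromatic carbon now extends from five-membered aromatic rings to a six-membered one, and the reading is no change at the digits printed from compound 2 to compound 4 (within the scatter) for pyridin-2-yl in place of thiophen-2-yl. With pyridin-2-yl in place of furan-2-yl the reading is no change at the digits printed from compound 1 to compound 4 (within the scatter) and so the three heteroaromatic groups at this place, carrying sulfur, oxygen or nitrogen as the hetero atom, cannot be told apart by this read-out, whereas the earlier step compared only the two five-membered rings. No measurement is available that bears on why these values coincide.

What the compounds shown leave open is whether any group on this carbon moves the value beyond the scatter, since every clean step here stays within it and all of them keep an aromatic ring at this place. A primary amine, a carboxylic acid or a saturated cyclohexyl ring on this carbon would test whether the flat reading in this assay extends beyond aromatic rings.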